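From phenoxymethyl to piperidin-1-yl on the amide side chain

The source may report more compounds than this note shows. Statements on the series, on what has been measured and on what is new or still open speak of the compounds shown alone.

In an ADME assay on CCRF-CEM cells (Homo sapiens) for cytotoxicity, read by cell counting (on this read-out higher numbers stand for lower toxicity in this test and lower numbers for higher toxicity in this test), compound 3 (`Cc1cc(C)cc(S(=O)(=O)c2c(C(=O)NCCOc3ccccc3)[nH]c3ccc(Br)cc23)c1`) reads > 500000 nM and this is a limit of the assay, not a number. Compound 4 (`Cc1cc(C)cc(S(=O)(=O)c2c(C(=O)NCN3CCCCC3)[nH]c3ccc(Br)cc23)c1`) keeps the core of compound 3 and has piperidin-1-yl in place of phenoxymethyl on a saturated chain carbon bound to an amide-type nitrogen. Two measured compounds bear on this change. Compound 1 (`Cc1cc(C)cc(S(=O)(=O)c2c(C(=O)NCc3ccccc3)[nH]c3ccc(Br)cc23)c1`) gives 172000 nM in this assay and differs from compound 3 at the same place. Among the compounds with values here, the one measured step there is an at least 2.9-fold higher number from compound 1 to compound 3 (0.46 log units; beyond the scatter) with phenoxymethyl in place of phenyl, so its true size remains open. Compound 2 (`Cc1cc(C)cc(S(=O)(=O)c2c(C(=O)NCN3CCCCC3)[nH]c3ccc([N+](=O)[O-])cc23)c1`) carries the same piperidin-1-yl group at that place, on a core that differs from that of compound 4, and as the closest guide compound 2 gives 12000 nM in this assay. Resting on compound 2 at 12000 nM and on compound 1 at 172000 nM as the nearest numbers, a large fall, beyond the scatter and towards higher toxicity, is expected. The expected change is an at least 16-fold lower number from compound 3 to compound 4 (1.22 log units; beyond the scatter) on this read-out. The estimated value for compound 4 is 30000 nM with an expected range from 8000 nM to 150000 nM in this assay once measured.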

Compound 4, half-maximal cytotoxic concentration: 10000 nM
For compound 4 the middle estimate is 3.0-fold (0.48 log units) above the measured one; measured number inside the range.
By their numbers in this assay, from the lowest: compounds 4 and 2 (each within the scatter of the next); then compound 1. At a limit, above all of these: compound 3.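

In this assay, piperidin-1-yl on a saturated chain carbon bound to an amide-type nitrogen goes with a lower number, towards higher toxicity in this test, against both other groups shown at this place: an at least 50-fold lower number from compound 3 to compound 4 (1.69 log units; beyond the scatter) and a 17-fold lower number from compound 1 to compound 4 (1.24 log units; beyond the scatter). With piperidin-1-yl held fixed, bromo in place of nitro on an aromatic carbon gives a 1.2-fold lower number from compound 2 to compound 4 (0.08 log units; within the scatter), so compound 2 and compound 4 cannot be told apart in this test and the two cores shown read alike with this side chain. The reading of compound 3 is a limit and not a number, so the true size of the step from it stays open: the limit of > 500000 nM in this assay, at which 1 of the 4 values shown sits.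

In the steps from compound 1 and compound 3, the nitrogen of the piperidin-1-yl ring enters as the six-membered aromatic ring of carbon only leaves, so the compounds shown do not tell which of the two changes goes with the lower number. Cyclohexyl at this place would bear on that question, while morpholin-4-yl or a longer chain carrying the piperidin-1-yl ring would show how much of this side chain can vary with the number staying this low.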